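Replacing 4-(dimethylamino)phenyl in compound 2 with 3-chlorophenyl

A few compounds are considered here, and "the series" means these few. Any claim that something is new, unique, unknown or untested is made for them only; others in the source may bear on it.

Of the compounds shown here, two with a shared core have been measured so far. In a functional assay on MCF7 cells (Homo sapiens) for inhibition, read by sulforhodamine B assay (on this read-out lower numbers stand for stronger inhibition of growth and higher numbers for weaker inhibition of growth), compound 1 `c1ccc(-c2ccc(-c3ccc(-c4nc5ccccc5[nH]4)cc3)cc2)cc1` gives 39200 nM, while compound 2 `Cc1ccc2[nH]c(-c3ccc(-c4ccc(-c5ccc(N(C)C)cc5)cc4)cc3)nc2c1` gives 3130 nM. Compound 2 therefore holds the lower of the two numbers, and the gap between them lies beyond the usual scatter. These two compounds differ in more than one place, so their gap does not isolate any single change.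

Compound 3 `Cc1ccc2[nH]c(-c3ccc(-c4ccc(-c5cccc(Cl)c5)cc4)cc3)nc2c1` keeps the rest of compound 2 but carries 3-chlorophenyl in place of 4-(dimethylamino)phenyl on an aromatic carbon, para to a large group (3-chlorophenyl in place of 4-(dimethylamino)phenyl on an aromatic carbon). For the measured compounds named here, no measured step shows what this replacement does. Going by the values given here, the only hint is that compound 1, which also has no 4-(dimethylamino)phenyl, stands at 39200 nM, and this is weak guidance. The expected change in this assay is a modest step of a 2.2-fold higher number from compound 2 to compound 3 (0.35 log units; beyond the scatter), toward a higher number and so weaker inhibition of growth. For compound 3 the estimated value is 7000 nM, with an expected range from 2200 nM to 22000 nM.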

Compound 3, concentration for 50% growth inhibition: 1210 nM
The estimate for compound 3 lay 5.8-fold (0.76 log units) above the measured number, outside the stated range (below it).
By their numbers in this assay, from the lowest: compound 3; then compound 2; then compound 1.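

In this assay, for the compounds shown here, putting 3-chlorophenyl in place of 4-(dimethylamino)phenyl gives a 2.6-fold lower number from compound 2 to compound 3 (0.41 log units; beyond the scatter), the first single change that can be read, and it runs toward stronger inhibition of growth. At this aromatic carbon, then, the 4-(dimethylamino)phenyl group is not required for the growth inhibition seen with compound 2, and a ring substituted with chlorine and carrying no hydrogen-bond acceptor by the count goes beyond it. No measurement here bears on why the number falls with this replacement.

With one replacement shown at this place, the compounds leave open whether the step belongs to the arrival of the chlorine, to where it sits on the ring, or simply to the loss of the dimethylamino group, and a plain phenyl, a fluorophenyl or a pyridyl at the same carbon would help to tell these apart. Also open is what the methyl group on the shared core contributes, since no single step among these compounds isolates it.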